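Extending the Hydroxyalkyl Chain on the Triazole Substituent

The source may report more compounds than this note shows. Statements on the series, on what has been measured and on what is new or still open speak of the compounds shown alone.

Compound 2 `Cc1ccc(-n2cc(CCO)nn2)cc1Nc1nccc(-c2cccnc2)n1` is one of two compounds examined in a functional assay on K562 cells (Homo sapiens) for inhibition, read by MTT assay, with a stated time of 72 h (a lower number here means a stronger inhibitor, a higher number a weaker inhibitor), where compound 2 gives 10700 nM. Among the compounds with values here, its only companion is compound 1 `COc1ccc(-c2cn(-c3ccc(C)c(Nc4nccc(-c5cccnc5)n4)c3)nn2)cc1C(F)(F)F`, which in this assay gives 11200 nM; the step of a 1.0-fold lower number from compound 1 to compound 2 (0.02 log units; within the scatter) lies within the scatter, so compound 2 stands alongside compound 1 rather than apart from it. Compound 3 `Cc1ccc(-n2cc(CCCCO)nn2)cc1Nc1nccc(-c2cccnc2)n1` has not yet been measured. It differs from compound 2 by 2-hydroxyethyl in place of hydroxy on a saturated chain carbon, two bonds along the chain from an aromatic carbon. Within the data shown here, the single measured step, a 1.0-fold lower number from compound 1 to compound 2 (0.02 log units; within the scatter), is the only one bearing on this change: swapping a large aromatic group for 2-hydroxyethyl in the same place on the shared core gave a step within the scatter. On that basis no step beyond the scatter is expected in this assay, and the expected step of a 1.1-fold lower number from compound 2 to compound 3 (0.03 log units; within the scatter) is close to none. Compound 3 is therefore estimated at 10000 nM, with a range from 4000 nM to 25000 nM.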

Compound 3, half-maximal inhibitory concentration: 11200 nM
For compound 3 the middle estimate is 1.1-fold (0.05 log units) below the measured one; low and high end bracket the measured number.
By their numbers in this assay, from the lowest: compounds 2, 1 and 3 (each within the scatter of the next).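

Replacing 2-hydroxyethyl with 4-hydroxybutyl gives a 1.0-fold higher number from compound 2 to compound 3 (0.02 log units; within the scatter) in this assay, so a change within the hydroxyalkyl chain itself, and not only the exchange of a large aromatic group for a chain, now stays inside the scatter at this position. Compared with the aromatic substituent, 4-hydroxybutyl in place of 4-methoxy-3-(trifluoromethyl)phenyl gives no change at the digits printed from compound 1 to compound 3 (within the scatter), so the two chain lengths and the aromatic group all stand together in this assay.

The compounds shown leave open whether any group at this position can move the number beyond the scatter, for instance an amine or a carboxylic acid in place of the hydroxy, or a longer chain. No supporting measurement is available to explain why these three compounds read alike.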